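This account rests on a few compounds, and the source may have more. Where it says the series, first, only, none or still open, it means among the compounds named here.

Of the compounds shown here, three from one scaffold have been tested in a functional assay on EL4 cells (Mus musculus) for antiproliferative activity, read by sulforhodamine B assay, with a stated time of 48 h; on this read-out lower numbers stand for stronger inhibition and higher numbers for weaker inhibition. Compound 1 `C[C@H]1N=C2C[C@H]3C[C@H](C3(C)C)[C@@]2(C)OC1=O` gives 27000 nM. Compound 2 `CC1(C)[C@@H]2CC3=N[C@@H](CCC(=O)O)C(=O)O[C@@]3(C)[C@H]1C2` gives 36000 nM. Compound 3 `CC1(C)[C@H]2CC3=N[C@H](CCC(=O)O)C(=O)O[C@]3(C)[C@@H]1C2` gives 30000 nM. The value of compound 3 sits alongside those of compound 1 and compound 2, with the gap to each within the usual scatter. Going a 1.1-fold higher number from compound 1 to compound 3 (0.05 log units; within the scatter), so swapping a small substituent for a longer acid-bearing chain on this carbon left the number essentially unchanged. Going a 1.2-fold lower number from compound 2 to compound 3 (0.08 log units; within the scatter), which rests on (the fact that compounds 2 and 3 differ only in the configuration as drawn); mirroring the whole molecule made no difference either.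

Compound 4 `CC1(C)[C@H]2CC3=NCC(=O)O[C@]3(C)[C@@H]1C2` has not yet been measured. It differs from compound 3 in one place: hydrogen in place of 2-carboxyethyl on a saturated ring carbon. The chain that carried the acid is thus removed entirely. Within the data shown here, the only measured step that bears on this position, from compound 1 to compound 3, was within the scatter, and the mirror-image step from compound 2 to compound 3 was likewise flat. On this evidence the step of no change at the digits printed from compound 3 to compound 4 (within the scatter) is expected to be none beyond the scatter, in no particular direction. Compound 4 is therefore estimated to give 30000 nM in this assay, with a range from 12000 nM to 75000 nM.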

Compound 4, half-maximal inhibitory concentration: > 300000 nM
Compound 4 was reported as a limit (the forecaster's own chance of this, stated with the estimate: 15%); middle value at least 10-fold (1.00 log units) from the limit.
By their numbers in this assay, from the lowest: compounds 1, 3 and 2 (each within the scatter of the next). At a limit, above all of these: compound 4.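

In this assay, compound 4 is reported only as a limit, > 300000 nM. Replacing the 2-carboxyethyl group with hydrogen on this saturated ring carbon, next to the ring nitrogen, gives an at least 10-fold higher number from compound 3 to compound 4 (1.00 log units; beyond the scatter), and replacing the methyl group with hydrogen at the same carbon gives an at least 11-fold higher number from compound 1 to compound 4 (1.04 log units; beyond the scatter). The earlier compounds shown here made this position look indifferent, since methyl and 2-carboxyethyl read alike there, with a 1.1-fold higher number from compound 1 to compound 3 (0.05 log units; within the scatter); the new result shows that, among compounds 1, 3 and 4, the choice between those two groups hardly shows in the number, whereas having only hydrogen on this carbon does.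

The compounds shown leave open whether a carbon group is needed here at all, or whether another small group, such as an amine or a hydroxyl, would serve as well as methyl, and whether a longer chain without the carboxylic acid, such as propyl, would read like 2-carboxyethyl. Because the value of compound 4 is a limit, the true size of both new steps also stays open, and the mirror image of compound 4 is not among the compounds shown.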